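The source may report more compounds than this note shows. Statements on the series, on what has been measured and on what is new or still open speak of the compounds shown alone.

Of the compounds shown here, three that share one core have been measured in a functional assay on CHO-K1 cells for antagonist activity at melanin-concentrating hormone receptor 1 (Homo sapiens), read by inositol phosphate accumulation, with stated times of 10 min and 45 min; a lower number here means a stronger inhibitor, a higher number a weaker inhibitor. Compound 3 `Cc1nc(N2CCC(N3CCCS3(=O)=O)CC2)nc2ccc(NC(=O)/C=C/c3ccc(OC(F)(F)F)cc3)cc12` gives 16 nM, the lowest of the three numbers shown. Compound 2 `Cc1nc(NCCCNS(C)(=O)=O)nc2ccc(NC(=O)/C=C/c3ccc(OC(F)(F)F)cc3)cc12` gives 32 nM, which lies within the scatter of compound 3, whereas compound 1 `Cc1ccc(/C=C/C(=O)Nc2ccc3nc(N4CCC(O)(C5CC5)CC4)nc(C)c3c2)cc1` gives 107 nM, a gap beyond the scatter. Compound 4 `Cc1nc(N2CCC(NS(=O)(=O)N(C)C)CC2)nc2ccc(NC(=O)/C=C/c3ccc(OC(F)(F)F)cc3)cc12` has not yet been measured. It differs from compound 3 in one place: a group of 7 heavy atoms (2 carbon, 2 nitrogen, 2 oxygen, 1 sulfur; no ring) in place of a group of 7 heavy atoms (3 carbon, 1 nitrogen, 2 oxygen, 1 sulfur; one five-membered non-aromatic ring with 2 hetero atoms), on a saturated ring carbon The five-membered non-aromatic ring is replaced by a (dimethylsulfamoyl)amino group on the same saturated ring carbon. Going by the values given here, no measured pair shows a change of this kind, so the expectation rests on compound 3. The estimated step of a 1.1-fold higher number from compound 3 to compound 4 (0.05 log units; within the scatter) is expected to stay within the scatter, in no clear direction. Compound 4 is therefore expected to give 18 nM, in the range 8 nM to 45 nM.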

Compound 4, half-maximal inhibitory concentration: 31 nM
For compound 4 the middle estimate is 1.7-fold (0.24 log units) below the measured one; low and high end bracket the measured number.
By their numbers in this assay, from the lowest: compounds 3, 4 and 2 (each within the scatter of the next); then compound 1.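

In this assay, replacing the five-membered ring on this saturated ring carbon with the open-chain (dimethylsulfamoyl)amino group gives a 1.9-fold higher number from compound 3 to compound 4 (0.29 log units; within the scatter), a step that stays within the scatter. For this pair, the ring is therefore not required for a value in this range, and the change from no hydrogen-bond donor to one leaves the two numbers within the scatter. No measurement shown gives a reason for this step.

The compounds shown leave open whether an amine or a carboxylic acid on this ring carbon would also stay within the scatter of compound 3.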